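A Bromine Where Compound 3 Carries Only Hydrogen

This account rests on a few compounds, and the source may have more. Where it says the series, first, only, none or still open, it means among the compounds named here.

Compound 3 `COc1cc(OC)c(OC)cc1/C=C/C(=O)c1ccccc1` joins a trimethoxy-bearing ring to a plain phenyl ketone through the shared core. In a functional assay on SW982 cells (Homo sapiens) for inhibition, read by MTT assay, with a stated time of 72 h (a lower number here means a stronger inhibitor, a higher number a weaker inhibitor), compound 3 gives only a limit, > 150000 nM. Compound 1 `COc1cc(OC)c(OC)cc1/C=C/C(=O)c1ccc([N+](=O)[O-])cc1` carries a nitro group on that phenyl ring, and in this assay compound 1 likewise reaches only a limit, > 150000 nM. Compound 2 `COc1ccc(C(=O)/C=C/c2cc(OC)c(OC)cc2OC)cc1` carries a methoxy group instead, and in this assay compound 2 gives 60500 nM. Among the three, only compound 2 yields a number; the limit of > 150000 nM in this assay, at which 2 of the 3 values shown sit, marks where the other two rest. The measured steps are an at least 2.4-fold higher number from compound 2 to compound 3 (0.39 log units; beyond the scatter), an at least 2.4-fold lower number from compound 1 to compound 2 (0.39 log units; beyond the scatter) and a step that the two limits leave unreadable from compound 1 to compound 3.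

Compound 4 `COc1cc(OC)c(OC)cc1/C=C/C(=O)c1ccc(Br)cc1` differs from compound 3 by bromo in place of hydrogen on an aromatic carbon. The step from compound 2 to compound 3 shows that methoxy at this place lowers the number by a readable margin, while the nitro of compound 1 leaves no readable step; bromo is neither group, so the data give no firm direction, and a value still at or near the limit remains quite possible. The expected step is an at least 1.3-fold lower number from compound 3 to compound 4 (0.13 log units; that floor lies within the scatter), a guess rather than a reading. Compound 4 is therefore expected near 110000 nM, with a range from 35000 nM to 300000 nM.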

Compound 4, half-maximal inhibitory concentration: 38200 nM
The estimate for compound 4 lay 2.9-fold (0.46 log units) above the measured number, and the stated range covers the measured number.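

In this assay, among the compounds shown here, the change from phenyl to 4-bromophenyl gives an at least 3.9-fold lower number from compound 3 to compound 4 (0.59 log units; beyond the scatter), so methoxy is no longer the only group at this place on an aromatic carbon that brings the assay down to a readable number. Bromo and methoxy cannot be told apart here, since the swap between them gives a 1.6-fold lower number from compound 2 to compound 4 (0.20 log units; within the scatter), and the earlier compounds alone could not show that a group quite unlike methoxy would land level with it. The swap from nitro to bromo gives an at least 3.9-fold lower number from compound 1 to compound 4 (0.59 log units; beyond the scatter), so among the four compounds the group at this one place decides the outcome: bromo and methoxy give numbers, while nitro and hydrogen do not.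

From the compounds shown here alone, the true sizes of the two steps that start from compound 1 and compound 3 remain unknown, and they are only floors because those compounds rest on a limit: the limit of > 150000 nM in this assay, at which 2 of the 4 values shown sit. Also open is whether chloro, an amine or a carboxylic acid at this place would give a readable number as well, and whether bromo would do the same at another place on the ring.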